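A few compounds are considered here, and "the series" means these few. Any claim that something is new, unique, unknown or untested is made for them only; others in the source may bear on it.

Measured so far:
compound 1, `N#CC1=C(N)Oc2c(c3nc4ccccc4nc3c3ccccc23)C12C(=O)N(Cc1cnnn1-c1ccc(S(N)(=O)=O)cc1)c1ccccc12`: > 50000 nM
compound 2, `Cc1ccccc1-n1nncc1CN1C(=O)C2(C(C#N)=C(N)Oc3c(N)cc4nc5ccccc5nc4c32)c2ccccc21`: > 50000 nM

Both values come from an ADME assay on L02 cells (Homo sapiens) for antiproliferative activity, read by MTT assay, with a stated time of 48 h; a lower number here means a stronger inhibitor, a higher number a weaker inhibitor. The value given for compound 1 is a limit of the assay, not a number. The value given for compound 2 is likewise a limit of the assay, not a number, so compound 2 stands at the limit itself and cannot be placed in order against compound 1. Both results sit at the same point: the limit of > 50000 nM in this assay, at which 2 of the 2 values shown sit.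

Compound 3, `Cc1cc(C)cc(-n2nncc2CN2C(=O)C3(C(C#N)=C(N)Oc4c(N)cc5nc6ccccc6nc5c43)c3ccccc32)c1`, has not yet been measured. It differs from compound 2 in one place: 3,5-dimethylphenyl in place of 2-methylphenyl on an aromatic nitrogen. For the measured compounds named here, no pair of measured compounds is joined by a single change, so there is no measured step to lean on. The two measured values agree with each other, and a change of this kind gives no ground to expect a step beyond the usual scatter in either direction. The step expected from compound 2 to compound 3 is a step that the limit leaves unreadable from compound 2 to compound 3. For compound 3 the estimated value is 60000 nM, with an expected range from 30000 nM to 150000 nM, and the assay would most likely again report only a limit.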

Compound 3, half-maximal inhibitory concentration: > 50000 nM
Compound 3 gave a limit, no number; the forecaster's own chance of this, stated with the estimate: 85%; the middle value does not contradict the limit.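

In this assay, compound 2 and compound 3 each return only a limit of the assay rather than a number, so no step can be read between them. The compounds shown leave open whether 3,5-dimethylphenyl and 2-methylphenyl on the aromatic nitrogen differ at all, and what true value any of the three compounds has, as they share one result: the limit of > 50000 nM in this assay, at which 3 of the 3 values shown sit.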